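A few compounds are considered here, and "the series" means these few. Any claim that something is new, unique, unknown or untested is made for them only; others in the source may bear on it.

Compound 1 `CC(=O)OCC(CCn1cc(C#CCc2ccccc2)c(=O)n(C(=O)c2ccccc2)c1=O)COC(C)=O` gives 26800 nM in a functional assay on MCF7 cells (Homo sapiens) for antiproliferative activity, read by MTT assay, with a stated time of 72 h; a higher number here means a weaker inhibitor, a lower number a stronger inhibitor.
Compound 2 `O=c1[nH]c(=O)n(CCC(CO)CO)cc1C#Cc1cc(F)cc(F)c1` gives 63100 nM in this assay.

Compound 2 holds the higher of the two numbers; compound 1 sits a step below it, a gap beyond the usual scatter. Compound 3 `CCCCCCCCC#Cc1cn(CCC(CO)CO)c(=O)[nH]c1=O` differs from compound 2 by octyl in place of 3,5-difluorophenyl on a triple-bonded carbon. For the measured compounds named here, no measured pair shows this exchange, so its direction is unknown, and a step not far beyond the scatter, in either direction, is expected. The step this estimate implies is a 1.6-fold lower number from compound 2 to compound 3 (0.20 log units; within the scatter). Compound 3 is expected to give 40000 nM, with a range from 10000 nM to 150000 nM.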

Compound 3, half-maximal inhibitory concentration: 40300 nM
Estimate against measurement, compound 3: 1.0-fold (0.00 log units) below; the measured number falls inside the stated range.
By their numbers in this assay, from the lowest: compounds 1, 3 and 2 (each within the scatter of the next, the first and the last beyond it).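

In this assay, for the compounds shown here, octyl in place of 3,5-difluorophenyl on a triple-bonded carbon gives a 1.6-fold lower number from compound 2 to compound 3 (0.19 log units; within the scatter), the first comparison here of compounds that differ in one place. At this position, a chain with no ring and a six-membered aromatic ring of the same heavy-atom count are thus not told apart beyond the scatter. No evidence is available to explain this result. Still open, as far as these compounds go, is whether a longer chain, or a chain ending in an amine or a carboxylic acid, would stay within the scatter of compound 3.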